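A few compounds are considered here, and "the series" means these few. Any claim that something is new, unique, unknown or untested is made for them only; others in the source may bear on it.

Of the compounds shown here, three built on one shared core have been tested in a functional assay on SGC-7901 cells (Homo sapiens) for inhibition, read by MTT assay, with a stated time of 72 h; on this read-out lower numbers stand for stronger inhibition of growth and higher numbers for weaker inhibition of growth. Compound 1 `CC1=C(CCCCCCCCCCn2cc(C[C@H](O)COCCOC[C@@H](O)Cc3ccc(-c4ccccc4)cc3)nn2)C(=O)c2ccccc2C1=O` gives 390 nM, and compound 2 `COC1=C(C)C(=O)C(CCCCCCCCCCn2cc(C[C@H](O)COCCOC[C@@H](O)Cc3ccc(-c4ccccc4)cc3)nn2)=C(C)C1=O` gives 505 nM. Compound 3 `O[C@H](COCCOC[C@@H](O)Cc1cn(-c2ccc3c(c2)OCCO3)nn1)Cc1ccc(-c2ccccc2)cc1` differs from both in what sits on an aromatic nitrogen, and in this assay compound 3 gives 6400 nM, the highest of the three numbers, clearly separated from compounds 1 and 2 by gaps beyond the scatter. Compound 4 `O=c1[nH]c2ccc(-n3cc(C[C@H](O)COCCOC[C@@H](O)Cc4ccc(-c5ccccc5)cc4)nn3)cc2s1` is compound 3 with a single change: a group of 10 heavy atoms (7 carbon, 1 nitrogen, 1 oxygen, 1 sulfur; one five-membered aromatic ring with 2 hetero atoms, one six-membered aromatic ring of carbon only) in place of a group of 10 heavy atoms (8 carbon, 2 oxygen; one six-membered non-aromatic ring with 2 hetero atoms, one six-membered aromatic ring of carbon only), on an aromatic nitrogen. Going by the values given here, no measured pair shows this kind of exchange, so no step size is known from the data. For the step of a 1.3-fold lower number from compound 3 to compound 4 (0.11 log units; within the scatter) no change beyond the scatter is expected, in either direction. Compound 4 is therefore estimated at 5000 nM, with a range from 2000 nM to 13000 nM.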

Compound 4, concentration for 50% growth inhibition: 10500 nM
Beside the measured number, compound 4's estimate is 2.1-fold (0.32 log units) below it; the measured number falls inside the stated range.
By their numbers in this assay, from the lowest: compounds 1 and 2 (each within the scatter of the next); then compounds 3 and 4 (each within the scatter of the next).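

In this assay, placing the entering group on the aromatic nitrogen in place of 2,3-dihydro-1,4-benzodioxin-6-yl gives a 1.6-fold higher number from compound 3 to compound 4 (0.22 log units; within the scatter). At this position, then, two groups of 10 heavy atoms cannot be told apart on this read-out, although the entering group has a hydrogen-bond donor and the leaving group has none. Nothing measured here offers an explanation for this result. Still open, on these data alone, is whether a simple phenyl group on this nitrogen would give a number beyond the scatter. Equally open, as far as these compounds go, is whether a carboxylic acid or an amine on such a group would do so.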